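A few compounds are considered here, and "the series" means these few. Any claim that something is new, unique, unknown or untested is made for them only; others in the source may bear on it.

Working notes on the series. In a functional assay on MNK45 cells (Homo sapiens) for inhibition, read by MTT assay, with a stated time of 48 h (a lower number here means a stronger inhibitor, a higher number a weaker inhibitor), compound 3 `Cc1ccc(NC(=O)NC(=O)c2ccc(OCc3ccc(C(F)(F)F)cc3)cc2)cc1-c1nc2ccccc2[nH]1` gives 16800 nM, the lowest of the two numbers in hand. Compound 1 `Cc1ccc(NC(=S)NC(=O)c2ccc(OCc3ccccc3)cc2)cc1-c1nc2ccccc2[nH]1` gives 57800 nM in this assay, a higher number. Compound 2 `Cc1ccc(NC(=S)NC(=O)c2ccc(OCc3cccc(Cl)c3Cl)cc2)cc1-c1nc2ccccc2[nH]1` returns only a limit in this assay, > 100000 nM. Compound 3 and compound 1 differ in two places, so their gap is not read as a single step. The change to compound 4 `Cc1ccc(NC(=O)NC(=O)c2ccc(OCc3ccccc3Cl)cc2)cc1-c1nc2ccccc2[nH]1` is 2-chlorophenyl in place of 4-(trifluoromethyl)phenyl on a saturated chain carbon bound to an oxygen on an aromatic ring. Within the data shown here, the one measured step at the same place is an at least 1.7-fold higher number from compound 1 to compound 2 (0.23 log units; that floor lies within the scatter), which ran between compound 1 and compound 2 and ended at the limit of > 100000 nM in this assay, at which 1 of the 3 values shown sits, so its true size is known only by its floor. That step gives no sign that a chlorine on the benzyl ring lowers the number; if anything it points the other way. Among the measured compounds shown here, no measured step separates a trifluoromethyl from a chloro at this place. The expectation for compound 4 is therefore a step of a 2.1-fold higher number from compound 3 to compound 4 (0.32 log units; beyond the scatter), upward, with a real chance of a limit. The estimated value for compound 4 is 35000 nM, within a range of 12000 nM to 100000 nM.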

Compound 4, half-maximal inhibitory concentration: 21500 nM
Compound 4: the middle estimate sits 1.6-fold (0.21 log units) above what was measured, within the range that was stated.
By their numbers in this assay, from the lowest: compounds 3 and 4 (each within the scatter of the next); then compound 1. At a limit, above all of these: compound 2.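

Among these compounds, the step of a 1.3-fold higher number from compound 3 to compound 4 (0.11 log units; within the scatter) is the first at this place, on a saturated chain carbon bound to an oxygen on an aromatic ring, with a measured number at both ends, and it gives a reading in this assay that the earlier floor could not. With the rest of the molecule unchanged, 2-chlorophenyl and 4-(trifluoromethyl)phenyl cannot be told apart in this read-out, even though both the substituent and its printed ring position change together. Nothing shown gives a cause for this result.

Going by these compounds, whether any group at this place moves the number beyond the scatter stays open, since a carboxylic acid or an amine on the benzyl ring would be a wider change than these two. Also open is the effect of the thiocarbonyl of compound 1 alone, as no pair shown differs only there.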